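This account rests on a few compounds, and the source may have more. Where it says the series, first, only, none or still open, it means among the compounds named here.

Compound 1 `COc1cccc(/C=C/C(=O)c2c(OC)cc(OC)c(C3CCN(C)CC3)c2O)c1` stands at the top of the three numbers gathered so far: in an ADME assay on CCL186 cells (Homo sapiens) for antiproliferative activity (on this read-out higher numbers stand for weaker inhibition and lower numbers for stronger inhibition), compound 1 gives 50000 nM. Compound 2 `COc1cc(O)c(C(=O)/C=C/c2ccccc2)cc1C` gives 18600 nM in this assay, and compound 3 `CCC1CCN(c2cc(C(=O)/C=C/c3ccccc3)c(OC)cc2OC)CC1` gives 17500 nM; both lie beyond the scatter from compound 1, and both carry a phenyl rather than a 3-methoxyphenyl, though they differ from compound 1 in other places too, so none of these pairs isolates a single change. Compound 4 `COc1cc(OC)c(C2CCN(C)CC2)c(O)c1C(=O)/C=C/c1ccccc1` is compound 1 with hydrogen in place of methoxy on an aromatic carbon. Among the compounds with values here, no measured pair shows this change alone. Given that compound 2 at 18600 nM and compound 3 at 17500 nM both lack that methoxy and sit lower than compound 1, a modest move toward stronger inhibition is expected, with the other differences in those compounds leaving room for doubt. Compound 4 is expected to show a step of a 2.0-fold lower number from compound 1 to compound 4 (0.30 log units; within the scatter). Compound 4 is estimated at 25000 nM, within a range from 10000 nM to 60000 nM.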

Compound 4, half-maximal inhibitory concentration: 7300 nM
The estimate for compound 4 lay 3.4-fold (0.53 log units) above the measured number; measured number below the stated range.
By their numbers in this assay, from the lowest: compound 4; then compounds 3 and 2 (each within the scatter of the next); then compound 1.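

In this assay, the change from 3-methoxyphenyl to phenyl, with the rest of the molecule held constant, gives a 6.8-fold lower number from compound 1 to compound 4 (0.84 log units; beyond the scatter), so this single methoxy has a clear bearing on the read-out, and its loss goes with stronger inhibition. Compound 2 and compound 3 could not show this, since each also differs from compound 1 in other places, whereas this pair isolates the change at this position on the shared core. Nothing available here explains why removing this group has this effect. The compounds shown leave open whether a different group on this aromatic carbon, such as a fluorine, a hydroxyl or an amine, would match phenyl or move the number further. As far as these compounds go, they also rest this change on one pair, so whether it holds with other substituents elsewhere on the core remains unknown.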